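A few compounds are considered here, and "the series" means these few. Any claim that something is new, unique, unknown or untested is made for them only; others in the source may bear on it.

Compound 1 `Cc1c(C)c2c(c(C)c1N)CC(C)(C)O2`: 7.8 mg/kg
Compound 2 `Cc1c(C)c2c(c(N)c1N)CC(C)(C)O2`: > 50 mg/kg, a limit of the assay
Compound 3 `Cc1c(C)c2c(c(C)c1N)CC(C)(CSc1ccc(F)cc1)O2`: 17.9 mg/kg

In a functional assay on the whole organism with Mus musculus as the target (a higher number here means that more compound is needed for the effect, a lower number that less compound is needed), compound 3 gives 17.9 mg/kg, a higher number than compound 1 at 7.8 mg/kg, and that gap lies beyond the scatter. Compound 4 `Cc1c(C)c2c(c(C)c1N)CC(C)(CSc1nccn1C)O2` carries 1-methyl-1H-imidazol-2-yl in place of 4-fluorophenyl on a sulfur. For the measured compounds named here, the only measured step, an at least 6.4-fold higher number from compound 1 to compound 2 (0.80 log units; beyond the scatter), is a change of amino in place of methyl on an aromatic carbon, so it does not test this place. Going by the values given here, with no measured step to suggest a direction, the expected change is small: a 1.1-fold lower number from compound 3 to compound 4 (0.05 log units; within the scatter), within the scatter. For compound 4 the estimated value is 16 mg/kg, with an expected range of 6 mg/kg to 45 mg/kg.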

Compound 4, dose for 50% inhibition: 37.1 mg/kg
Compound 4: middle estimate off by 2.3-fold (0.37 log units), on the low side; the range from low to high includes it.
By their numbers in this assay, from the lowest: compound 1; then compound 3; then compound 4. At a limit, above all of these: compound 2.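

Changing the group on this sulfur does shift the dose in this assay: 1-methyl-1H-imidazol-2-yl in place of 4-fluorophenyl gives a 2.1-fold higher number from compound 3 to compound 4 (0.32 log units; beyond the scatter). Against hydrogen on the saturated chain carbon, the (1-methyl-1H-imidazol-2-yl)sulfanyl group gives a 4.8-fold higher number from compound 1 to compound 4 (0.68 log units; beyond the scatter), so more compound is needed with this group than without it. Nothing measured here explains the direction of either step. Still open, as far as these compounds go, is whether an unsubstituted phenyl or a pyridine ring on this sulfur would need less compound than compound 3. An amine in place of the sulfanyl group is equally untested against compound 1.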